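A Shorter Side Chain on a Purine Glycinamide

The source may hold more compounds than are shown below. What is called first, only, known or untested is meant among the compounds shown, and "the series" means these compounds.

Compound 2, `O=C(CN(c1ncnc2c1ncn2C1CCCCO1)C1CC1)N[C@@H](CCC(=O)OCc1ccccc1)C(=O)OCc1ccccc1`, was examined in a functional assay on the whole organism (Tail, strain ICR) with Mus musculus as the target, in the tail flick test, with a stated time of 120 min, at a dose of 25 umol/kg by the oral route (a higher number here means a stronger effect of the compound at the dose given, a lower number a weaker effect), where compound 2 gives 20.7%. Within the data shown here, compound 1, `CC(C)[C@H](NC(=O)CN(c1nc(Cl)nc2[nH]cnc12)C1CC1)C(=O)OCc1ccccc1`, is the only other measured compound, and in this assay compound 1 gives 27.3%. Compound 2 thus stands as the lower of the two numbers, but the two values lie within the scatter of each other, so no order between them can be drawn. The next compound is compound 3, `C[C@H](NC(=O)CN(c1ncnc2c1ncn2C1CCCCO1)C1CC1)C(=O)OCc1ccccc1`. The change from compound 2 is hydrogen in place of (benzyloxycarbonyl)methyl on a saturated chain carbon, two bonds along the chain from an amide-type nitrogen and a carbonyl carbon. Among the measured compounds shown here, no measured pair in this set shows the same change, so there is nothing to anchor its size; the expectation is that the step of a number 1.3 percentage points higher from compound 2 to compound 3 (within the scatter) stays within the scatter, with no clear direction. On that basis compound 3 is expected to give 22% in this assay, estimated to fall between 5% and 40%.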

Compound 3, a percentage reported as activity, at one dose (the size of the read-out at that dose, not a potency): 25.3%
Compound 3: the middle estimate sits 3.3 percentage points below what was measured; the range from low to high includes it.
By their numbers in this assay, from the lowest: compounds 2, 3 and 1 (each within the scatter of the next).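

Putting hydrogen in place of (benzyloxycarbonyl)methyl on a saturated chain carbon, two bonds along the chain from an amide-type nitrogen and a carbonyl carbon, gives a number 4.6 percentage points higher from compound 2 to compound 3 (within the scatter) in this assay. Among these compounds, this is the first reading at this position: for this one pair, at this one dose, the 11 heavy atoms of that group, with their six-membered aromatic ring of carbon only, can be exchanged for hydrogen with no difference that stands clear of the scatter. Nothing available on these compounds speaks to what lies behind this reading.

On these data alone, whether a carboxylic acid, an amine or a longer chain at this carbon would give a number clear of the scatter remains open. Compound 1 differs from compound 3 in more than one place, so it cannot settle this.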